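The compounds below may be only part of what the source reports. "The series", "measured", "known", "first", "only" and "open" are said of these compounds alone.

Compound 2 `C[Se]c1nc2ccccc2s1` is the reference point here. In a functional assay on MCF7 cells (Homo sapiens) for cytotoxicity, read by MTT assay, with a stated time of 72 h (on this read-out higher numbers stand for weaker inhibition of growth and lower numbers for stronger inhibition of growth), compound 2 gives > 100000 nM, which is a limit of the assay and not a number. Among the measured compounds shown here, compound 1 `[SeH]c1nc2ccccc2s1` is the only other measured compound. In this assay compound 1 gives > 50000 nM, likewise a limit rather than a number. For the measured compounds named here, the single measured step, a step that the two limits leave unreadable from compound 1 to compound 2, cannot be sized because the limit of > 100000 nM in this assay, at which 1 of the 2 values shown sits, and the limit of > 50000 nM in this assay, at which 1 of the 2 values shown sits, are all that its two values show.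

Compound 3 `N#CSc1nc2ccccc2s1` carries a different change: a group of 3 heavy atoms (1 carbon, 1 nitrogen, 1 sulfur; no ring) in place of a group of 2 heavy atoms (1 carbon, 1 selenium; no ring), on an aromatic carbon. Going by the values given here, no measured step concerns a change of this kind, and the one step available has no readable size, so no direction of change is expected beyond the scatter; compound 3 is estimated to give 80000 nM, in a range from 15000 nM to 300000 nM. The step from compound 2 to compound 3 is expected to be an at least 1.2-fold lower number from compound 2 to compound 3 (0.09 log units; that floor lies within the scatter).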

Compound 3, concentration for total growth inhibition: 67600 nM
Compound 3: middle estimate off by 1.2-fold (0.07 log units), on the high side; measured number inside the range.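

In this assay, among the compounds shown here, the cyanosulfanyl group on this aromatic carbon gives the first value at this position that is a number and not a limit. Set against the selenium-bound methyl group of compound 2, this change is an at least 1.4-fold lower number from compound 2 to compound 3 (0.17 log units; that floor lies within the scatter), so the data fix only a floor for the step and do not yet show a clear gain in growth inhibition. Compound 1 has a limit and not a number, so its step to compound 3 cannot be read: the limit of > 50000 nM in this assay, at which 1 of the 3 values shown sits.

On these data alone, it remains open whether the sulfur or the nitrile matters more here, a question that a methylsulfanyl group or a selenium atom carrying a nitrile could help separate. As far as these compounds go, how an amine, a carboxylic acid or a longer chain on this carbon would read in this assay is also open.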